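Cytotoxicity notes: methyl to cyano on the phenyl ring

The source may report more compounds than this note shows. Statements on the series, on what has been measured and on what is new or still open speak of the compounds shown alone.

Compound 1 `Cc1ccc(-c2csc(N3N=C(c4ccc(C)s4)CC3c3ccc(F)cc3)n2)cc1` is known in an ADME assay on NIH3T3 cells (Mus musculus) for cytotoxicity, read by XTT assay, with a stated time of 24 h (on this read-out higher numbers stand for weaker inhibition and lower numbers for stronger inhibition), only as a limit of the assay. In this assay compound 1 gives > 500 ug/mL. Compound 2 `Cc1ccc(-c2csc(N3N=C(c4ccc(Cl)s4)CC3c3ccc(F)cc3)n2)cc1`, which carries chloro in place of methyl on an aromatic carbon, is likewise known only as a limit. In this assay compound 2 gives > 500 ug/mL. The step that the two limits leave unreadable from compound 1 to compound 2 therefore cannot be read, because of the limit of > 500 ug/mL in this assay, at which 2 of the 2 values shown sit. Compound 3 `Cc1ccc(C2=NN(c3nc(-c4ccc(C#N)cc4)cs3)C(c3ccc(F)cc3)C2)s1` is the next member and differs from compound 1 by cyano in place of methyl on an aromatic carbon. Among the compounds with values here, no measured step touches the 4-methylphenyl group, and the single measured step leaves no readable size, so nothing points to a change in cytotoxicity beyond the scatter, in either direction. The expectation for compound 3 in this assay is therefore that it will again sit at the limit, and the step of a number no higher from compound 1 to compound 3 (the limit leaves the size open) is estimated as none beyond the scatter. Compound 3 is estimated at 500 ug/mL in this assay, with a range from 200 ug/mL to 1000 ug/mL.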

Compound 3, half-maximal inhibitory concentration: 250 ug/mL
The estimate for compound 3 lay 2.0-fold (0.30 log units) above the measured number; the range from low to high includes it.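

In this assay, the change from 4-methylphenyl to 4-cyanophenyl gives an at least 2.0-fold lower number from compound 1 to compound 3 (0.30 log units; that floor lies within the scatter). Within the data shown here, compound 3 is the first to give a number and not a limit, so this place on the six-membered aromatic ring is the first at which a change yields a readable step, whereas the step from compound 1 to compound 2 cannot be read. That step is only a floor and the floor itself lies within the scatter, so the notes can record its direction but neither its true size nor whether it goes beyond the scatter: the limit of > 500 ug/mL in this assay, at which 2 of the 3 values shown sit.

The compounds shown leave open whether an amine, a carboxylic acid or a longer chain at this place would also give a number or would stay at the limit, and so whether the read-out depends on cyano specifically or on replacing methyl at all. Also open, going by these compounds, is whether cyano at this place would give a similar read-out on the background of compound 2, with chloro in place of methyl at the other site.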